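The source may report more compounds than this note shows. Statements on the series, on what has been measured and on what is new or still open speak of the compounds shown alone.

Compound 1 `CC(C)[C@H](NC(=O)COc1cccc2ccccc12)C(=O)N[C@@H](CC(=O)O)C(=O)COC(=O)c1c(Cl)cccc1Cl`: in a functional assay on Jurkat cells (Homo sapiens) (on this read-out higher numbers stand for weaker inhibition and lower numbers for stronger inhibition), compound 1 gives 10600 nM.
Compound 2 `CC(C)[C@H](NC(=O)COc1cccc2ccccc12)C(=O)N[C@@H](CC(=O)O)C(=O)COc1cccc(C(F)(F)F)c1`: in this assay compound 2 gives > 100000 nM, a limit of the assay.
Compound 3 `CC(C)[C@H](NC(=O)COc1cccc2ccccc12)C(=O)N[C@@H](CC(=O)O)C(=O)COc1ccccc1F`: in this assay compound 3 gives > 100000 nM, again a limit of the assay.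

Compound 3 thus sits at the limit of > 100000 nM in this assay, at which 2 of the 3 values shown sit, and no number is known for it. Compound 4 `CC(C)[C@H](NC(=O)COc1cccc2ccccc12)C(=O)N[C@@H](CC(=O)O)C(=O)COc1cc(F)cc(F)c1F` differs from compound 3 in one place: 2,3,5-trifluorophenyl in place of 2-fluorophenyl on an oxygen on a saturated carbon. Two measured steps reached that limit, an at least 9.4-fold higher number from compound 1 to compound 2 (0.97 log units; beyond the scatter) and an at least 9.4-fold higher number from compound 1 to compound 3 (0.97 log units; beyond the scatter), while a step that the two limits leave unreadable from compound 2 to compound 3 cannot be sized. Going by the values given here, no measured step exchanges one fluorinated phenyl for another, so the change from compound 3 to compound 4 has no direct counterpart. Compound 4 is expected to stay at the limit, the step being a number no higher from compound 3 to compound 4 (the limit leaves the size open). For compound 4 the estimate is 100000 nM, between 30000 nM and 300000 nM.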

Compound 4, half-maximal inhibitory concentration: 30000 nM
Compound 4: the middle estimate sits 3.3-fold (0.52 log units) above what was measured, and the stated range covers the measured number.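

In this assay, a phenyl group on this oxygen can come off the limit, with an at least 3.3-fold lower number from compound 3 to compound 4 (0.52 log units; beyond the scatter) and an at least 3.3-fold lower number from compound 2 to compound 4 (0.52 log units; beyond the scatter), so 2,3,5-trifluorophenyl gives a readable value where 2-fluorophenyl and 3-(trifluoromethyl)phenyl do not. Even so, (2,6-dichlorophenyl)carbonyl still gives the stronger inhibition, with a 2.8-fold higher number from compound 1 to compound 4 (0.45 log units; beyond the scatter). The two lower steps remain bounds only, as each starts from a limit of the assay: the limit of > 100000 nM in this assay, at which 2 of the 4 values shown sit.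

The compounds shown leave open which fluorine of 2,3,5-trifluorophenyl carries the gain. They also leave open whether a nitrile or a methoxy group on the phenyl ring would do the same.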